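Isopropyl to cyclopentyl in a microsomal stability series

This account rests on a few compounds, and the source may have more. Where it says the series, first, only, none or still open, it means among the compounds named here.

Values measured so far in an ADME assay (liver) for metabolic stability, with Liver microsome (Rattus norvegicus) as the target, read by LC-MS, using microsomes and NADPH, with stated times of 5 min and 60 min, tested at 4 uM (a lower number here means that less of the compound is left, a higher number that more of the compound is left), are
compound 1 `Cc1c(OCCCCOc2cccc(C(=O)O)c2)ccc(C(=O)CC2CCCC2)c1O` with 55%
compound 2 `Cc1ccc(C(=O)O)cc1OCCCCOc1ccc(C(=O)CC2CCCC2)c(O)c1C` with 9%
compound 3 `Cc1cc(OCCCCOc2ccc(C(=O)CC(C)C)c(O)c2C)ccc1C(=O)O` with 57%

Compound 3 gives 57% in this assay and cannot be told apart from compound 1, which gives 55% here, while compound 2 gives 9% and lies far lower.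

The next compound, compound 4 `Cc1cc(OCCCCOc2ccc(C(=O)CC3CCCC3)c(O)c2C)ccc1C(=O)O`, differs from compound 3 in one place. The change cyclopentyl in place of isopropyl on a saturated chain carbon bound to a carbonyl carbon puts cyclopentyl in place of isopropyl on a saturated chain carbon bound to a carbonyl carbon.

Among the measured compounds shown here, no measured step makes this exchange. The only one available, a number 46 percentage points lower from compound 1 to compound 2 (beyond the scatter) and thus a large one, is methyl in place of hydrogen on an aromatic carbon, so it bears only indirectly, showing that values in this small set can move far on a single change. Cyclopentyl is already present in two measured compounds, with compound 1 at 55% and compound 2 at 9% in the same assay, so it is found at both ends of the range. A moderate fall, only somewhat beyond the scatter, is therefore expected in this assay with wide uncertainty. The estimated change is a number 15 percentage points lower from compound 3 to compound 4 (beyond the scatter) and it could prove larger or vanish. Compound 4 is expected at 42% with an estimated range from 15% to 65% in this assay as things stand.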

Compound 4, percent of the compound remaining: 55%
Beside the measured number, compound 4's estimate is 13 percentage points below it, and the stated range covers the measured number.
By their numbers in this assay, from the lowest: compound 2; then compounds 1, 4 and 3 (each within the scatter of the next).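

In this assay, cyclopentyl in place of isopropyl on a saturated chain carbon bound to a carbonyl carbon gives a number 2 percentage points lower from compound 3 to compound 4 (within the scatter) and so, in this one pair, the two groups cannot be told apart at this position. With cyclopentyl held in place, the read-out instead separates on the group on the oxygen on a saturated carbon: 4-carboxy-3-methylphenyl in place of 5-carboxy-2-methylphenyl gives a number 46 percentage points higher from compound 2 to compound 4 (beyond the scatter) while 4-carboxy-3-methylphenyl in place of 3-carboxyphenyl gives no change at the digits printed from compound 1 to compound 4 (within the scatter) and the cyclopentyl group thus appears at both high and low values, depending on that other group. Nothing available explains why either exchange has the size it has.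

Among the compounds shown here, the exchange is seen only with 4-carboxy-3-methylphenyl on the oxygen, so it remains open whether isopropyl and cyclopentyl would also match with 5-carboxy-2-methylphenyl there. Also open, from the compounds shown here alone, is how this assay would respond at the same position to a cyclohexyl group or a straight butyl chain, or to an amide in place of the carboxylic acid.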